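The source may report more compounds than this note shows. Statements on the series, on what has been measured and on what is new or still open speak of the compounds shown alone.

Compound 1 `CCOc1ccc(Cl)cc1-c1cc(Nc2ccc(Cl)cc2)nc(N)n1` gives 17 nM in an assay on Sf9 cells for inhibition of 1-acyl-sn-glycerol-3-phosphate acyltransferase beta (Homo sapiens); a higher number here means a weaker inhibitor, a lower number a stronger inhibitor.
Compound 2 `CCOc1ccc(Cl)cc1-c1cc(Nc2ccccc2Cl)nc(N)n1` gives 4900 nM.
Compound 3 `CCOc1ccc(Cl)cc1-c1cc(Nc2ccc([N+](=O)[O-])cc2)nc(N)n1` gives 10 nM.

Compound 3 shows the lowest number of the three, although its gap to compound 1, a 1.7-fold lower number from compound 1 to compound 3 (0.23 log units; within the scatter), lies within the scatter, so the two cannot be ranked against each other. Compound 2 stands far away from both, as a 490-fold lower number from compound 2 to compound 3 (2.69 log units; beyond the scatter) makes plain.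

Compound 4 `CCOc1ccc(Cl)cc1-c1cc(Nc2cccc([N+](=O)[O-])c2)nc(N)n1` differs from compound 3 in one place: 3-nitrophenyl in place of 4-nitrophenyl on a nitrogen on an aromatic ring. Among the measured compounds shown here, two measured steps bear on this change, since both move or swap the substituent on the phenyl attached to that nitrogen. Shifting chloro from the 4-position to the 2-position gave a 290-fold higher number from compound 1 to compound 2 (2.46 log units; beyond the scatter), a large loss, and the reverse return to a 4-substituted phenyl gave a 490-fold lower number from compound 2 to compound 3 (2.69 log units; beyond the scatter). For the measured compounds named here, neither pair, however, shows what a 3-substituted phenyl does; the data hold no compound with that pattern. Given that the one measured shift away from the 4-position cost a great deal, a weakening is expected for compound 4, though its size is uncertain, estimated at a 10-fold higher number from compound 3 to compound 4 (1.00 log units; beyond the scatter). Compound 4 is therefore expected to give about 100 nM, within a range of 15 nM to 1500 nM.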

Compound 4, half-maximal inhibitory concentration: 640 nM
The estimate for compound 4 lay 6.4-fold (0.81 log units) below the measured number; low and high end bracket the measured number.
By their numbers in this assay, from the lowest: compounds 3 and 1 (each within the scatter of the next); then compound 4; then compound 2.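

In this assay, the place of the nitro group on the phenyl matters on its own: with the group itself unchanged, 3-nitrophenyl in place of 4-nitrophenyl gives a 64-fold higher number from compound 3 to compound 4 (1.81 log units; beyond the scatter) and turns a pair that could not be ranked into a clear loss. The loss is also seen against the chloro compound, with a 38-fold higher number from compound 1 to compound 4 (1.58 log units; beyond the scatter), yet it does not reach the level of the 2-chlorophenyl compound, as a 7.7-fold lower number from compound 2 to compound 4 (0.88 log units; beyond the scatter) shows, so in these four compounds the two 4-substituted phenyls hold the lowest numbers and neither of the other two patterns matches them. Nothing available explains why moving the nitro group costs this much.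

The compounds shown leave open whether chloro and nitro respond alike to the same change of place, as each appears here in only two patterns, so the effect of the position cannot be separated from that of the group for the 2-chlorophenyl compound. They also leave open whether a phenyl carrying an amine or a carboxylic acid at the 4-position would stay with compound 1 and compound 3.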